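Pyridyl amide variant of a pyrazole benzamide

This account rests on a few compounds, and the source may have more. Where it says the series, first, only, none or still open, it means among the compounds named here.

The account starts from compound 1 `O=C(Nc1cc(-c2ccccc2)nn1-c1ccccc1)c1ccccc1`, which in an assay on HEK293 cells for displacement of a labelled ligand from metabotropic glutamate receptor 5 (Rattus norvegicus) (on this read-out lower numbers stand for stronger inhibition and higher numbers for weaker inhibition), gives 4180 nM, the highest of the three numbers shown. Compound 2 `COc1cccc(-n2nc(-c3ccccc3)cc2NC(=O)c2ccccc2)c1` gives 2100 nM, and the step of a 2.0-fold lower number from compound 1 to compound 2 (0.30 log units; within the scatter) stays within the scatter. Compound 3 `O=C(Nc1cc(-c2ccccc2)nn1-c1ccccc1Br)c1ccc([N+](=O)[O-])cc1` gives 120 nM; it differs from compound 1 in more than one place, so its lower number cannot be tied to any single change. The unmeasured compound 4 `Cc1ccc(C(=O)Nc2cc(-c3ccccc3)nn2-c2ccccc2)cn1` differs from compound 1 by 6-methylpyridin-3-yl in place of phenyl on a carbonyl carbon. No measured step alters the group on the carbonyl carbon, so none of the steps shown bears directly on this change; the only single-place step, that from compound 1 to compound 2, was small and concerned a different position. With nothing to point either way, compound 4 is expected to sit near compound 1, the step of a 1.2-fold lower number from compound 1 to compound 4 (0.08 log units; within the scatter) being estimated to lie within the scatter. Compound 4 is therefore estimated at 3500 nM, with a range from 1000 nM to 12000 nM.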

Compound 4, inhibition constant: 3480 nM
The estimate for compound 4 lay 1.0-fold (0.00 log units) above the measured number; the range from low to high includes it.
By their numbers in this assay, from the lowest: compound 3; then compounds 2, 4 and 1 (each within the scatter of the next).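

In this assay, replacing phenyl with 6-methylpyridin-3-yl on the carbonyl carbon gives a 1.2-fold lower number from compound 1 to compound 4 (0.08 log units; within the scatter), the first single-place step shown at this group. Within the core of compound 1, this position therefore accepts a ring nitrogen and a methyl group together with no change beyond the scatter, although the step cannot separate the contribution of either one. No supporting evidence is available to explain this result.

The compounds shown leave open whether an unsubstituted pyridin-3-yl, or a phenyl carrying an amine or a carboxylic acid, would also leave the number unchanged at this position. They also leave open how much of the value of compound 3 comes from its nitro group and how much from its bromine, as the two differ from compound 1 together.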